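The source may hold more compounds than are shown below. What is called first, only, known or untested is meant among the compounds shown, and "the series" means these compounds.

In a functional assay on HepG2 cells (Homo sapiens) for antiproliferative activity, read by MTT assay, with a stated time of 48 h (a higher number here means a weaker inhibitor, a lower number a stronger inhibitor), compound 2, with structure `S=c1oc(-c2ccc3c(c2)OCCO3)nn1CN1CCN(c2cccc(Cl)c2)CC1`, gives > 50000 nM, and this value is a limit of the assay rather than a number. Compound 1, `S=c1oc(-c2ccc3c(c2)OCCO3)nn1CN1CCN(c2cccc(Cl)c2Cl)CC1`, also gives only a limit in this assay, at > 50000 nM. Among the compounds with values here, compound 3, `COc1cccc(N2CCN(Cn3nc(-c4ccc5c(c4)OCCO5)oc3=S)CC2)c1`, is the one measured compound with a true number in this assay, at 21400 nM. The step of an at least 2.3-fold lower number from compound 2 to compound 3 (0.36 log units; beyond the scatter) shows that exchanging the chloro for a methoxy moves the number downward, and an at least 2.3-fold lower number from compound 1 to compound 3 (0.36 log units; beyond the scatter) points the same way from the dichloro compound. The step that the two limits leave unreadable from compound 1 to compound 2 cannot be read because the limit of > 50000 nM in this assay, at which 2 of the 3 values shown sit, covers both of its ends.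

Compound 4, `O=[N+]([O-])c1ccc(N2CCN(Cn3nc(-c4ccc5c(c4)OCCO5)oc3=S)CC2)cc1`, has not yet been measured. It differs from compound 2 in one place: 4-nitrophenyl in place of 3-chlorophenyl on an amine nitrogen in a ring. Within the data shown here, the only measured step that touches this part of the molecule is an at least 2.3-fold lower number from compound 2 to compound 3 (0.36 log units; beyond the scatter), and it starts from a limit, so its true size is open. Among the measured compounds shown here, the series as a whole is weak in this assay, and the nitrophenyl group has no measured precedent here. The expected step of an at least 1.2-fold lower number from compound 2 to compound 4 (0.09 log units; that floor lies within the scatter) is therefore small, with a fair chance that only a limit is reported once more. For compound 4 in this assay the estimated value is 40000 nM, expected to lie between 15000 nM and 100000 nM.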

Compound 4, half-maximal inhibitory concentration: 29500 nM
Beside the measured number, compound 4's estimate is 1.4-fold (0.13 log units) above it; measured number inside the range.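

Compound 4 is the second compound in the series to give a true number rather than a limit in this assay, so this result no longer rests on the 3-methoxyphenyl group alone. The step of a 1.4-fold higher number from compound 3 to compound 4 (0.14 log units; within the scatter) means that the 4-nitrophenyl and 3-methoxyphenyl groups cannot be told apart here, even though the two groups differ in both their substituent and its place on the phenyl ring. Across the four compounds, the two with chlorine on this phenyl ring give limits and the two without it give true numbers, with none going against this; even so, the steps of an at least 1.6-fold lower number from compound 2 to compound 4 (0.22 log units; that floor lies within the scatter) and an at least 1.6-fold lower number from compound 1 to compound 4 (0.22 log units; that floor lies within the scatter) have floors that do not clear the scatter, and they give only floors because both start from a limit: the limit of > 50000 nM in this assay, at which 2 of the 4 values shown sit.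

Going by these compounds, the true size of those two steps therefore remains open, as does the question of whether the substituent or its place on the phenyl ring matters more. The compounds shown also leave open what a plain phenyl ring, or an amine or a carboxylic acid on that ring, would give in this assay.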